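This account rests on a few compounds, and the source may have more. Where it says the series, first, only, none or still open, it means among the compounds named here.

Measured compounds:
compound 1, `COc1ccc(C(=O)NC(CC(=O)O)c2ccc(C(C)(C)C)cc2)cc1`, > 100000 nM
compound 2, `CC(C)(C)c1ccc(C(CC(=O)O)NC(=O)c2ccc(C(F)(F)F)cc2)cc1`, 82300 nM
compound 3, `COc1ccc(C(=O)NC(CC(=O)O)c2ccc(Cl)cc2Cl)cc1`, > 100000 nM

In a functional assay on MDA-MB-436 cells (Homo sapiens) for antiproliferative activity, read by MTT assay, with a stated time of 24 h (a lower number here means a stronger inhibitor, a higher number a weaker inhibitor), the value of compound 1 is a limit of the assay, not a number. The value of compound 3 in this assay is likewise a limit. Compound 2 differs from compound 1 by trifluoromethyl in place of methoxy on an aromatic carbon, and this change gave an at least 1.2-fold lower number from compound 1 to compound 2 (0.08 log units; that floor lies within the scatter), the floor resting on (the limit of > 100000 nM in this assay, at which 2 of the 3 values shown sit). The difference between the cores of compound 1 and compound 3 is not broken down here.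

Compound 4, `O=C(O)CC(NC(=O)c1ccc(C(F)(F)F)cc1)c1ccc(Cl)cc1Cl`, is not yet measured in this assay. From compound 3 it differs by trifluoromethyl in place of methoxy on an aromatic carbon, the same kind of change as from compound 1 to compound 2. A similar small step, an at least 1.1-fold lower number from compound 3 to compound 4 (0.04 log units; that floor lies within the scatter), is expected, resting on an at least 1.2-fold lower number from compound 1 to compound 2 (0.08 log units; that floor lies within the scatter). Compound 4 is expected at about 90000 nM, from 45000 nM to 180000 nM, with a fair chance that only a limit is reported.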

Compound 4, half-maximal inhibitory concentration: 44100 nM
Compound 4: middle estimate off by 2.0-fold (0.31 log units), on the high side, outside the stated range (below it).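

In this assay, trifluoromethyl in place of methoxy on an aromatic carbon gives an at least 2.2-fold lower number from compound 3 to compound 4 (0.35 log units; beyond the scatter). This step lies beyond the scatter, while the floor of the earlier step on the core of compound 1 does not, so no equal or different carry-over between the two cores can be claimed: the same change on two cores in this assay, an at least 1.2-fold lower number (0.08 log units; that floor lies within the scatter) from compound 1 to compound 2 and an at least 2.2-fold lower number (0.35 log units; beyond the scatter) from compound 3 to compound 4; the limit leaves it open whether they differ. Both steps start from a limit, so each gives a floor and not a full size: the limit of > 100000 nM in this assay, at which 2 of the 4 values shown sit.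

Still open, as far as these compounds go, is how a nitrile or an amine would read in place of trifluoromethyl on either core. Also open, from the compounds shown here alone, is whether a longer chain carrying the carboxylic acid would change the reading in this assay.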